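This account rests on a few compounds, and the source may have more. Where it says the series, first, only, none or still open, it means among the compounds named here.

Working notes on a series of three measured compounds and one still to be measured in an assay on HEK293 cells for inhibition of transient receptor potential cation channel subfamily M member 2 (Homo sapiens), read by patch clamp, with a stated time of 60 s; on this read-out lower numbers stand for stronger inhibition and higher numbers for weaker inhibition.

Compound 1 `Cc1cc(Cl)cc2c1NC(c1c[nH]nc1-c1ccccc1)NC2=O` and compound 2 `Cc1cc(Br)cc2c1NC(c1c[nH]nc1-c1ccccc1)NC2=O` share one core and differ only at a single aromatic carbon, as chloro in place of bromo on an aromatic carbon sets out. In this assay compound 1 gives 5100 nM, and compound 2 gives 4600 nM. The step between them, a 1.1-fold higher number from compound 2 to compound 1 (0.04 log units; within the scatter), is within the usual scatter, so these two values are read as the same.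

Compound 3 `Cc1cc(Br)cc2c1NC(c1c[nH]nc1-c1cccc3ccccc13)NC2=O` carries a different core; how the core of compound 3 differs from that of compound 2 is not broken down here. In this assay compound 3 gives 3700 nM. Against compound 2 and compound 1 the values of compound 3 lie within the scatter, so no order among the three is read.

Compound 4 `Cc1cc(Cl)cc2c1NC(c1c[nH]nc1-c1cccc3ccccc13)NC2=O` is the unmeasured member. It differs from compound 3 by chloro in place of bromo on an aromatic carbon, with the place described in the same words as for the pair of compound 2 and compound 1, so this is the same change made once more, on the core of compound 3 instead of the core of compound 2.

Among the measured compounds shown here, the expected step from compound 3 to compound 4 is a 1.1-fold higher number from compound 3 to compound 4 (0.03 log units; within the scatter), rests on the only earlier instance of this change, a 1.1-fold higher number from compound 2 to compound 1 (0.04 log units; within the scatter), and is expected to stay within the scatter. On that basis compound 4 is estimated at 4000 nM, with a range from 2000 nM to 8000 nM.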

Compound 4, half-maximal inhibitory concentration: 4000 nM
Estimate against measurement, compound 4: no gap at the digits printed, within the range that was stated.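

In this assay, chloro in place of bromo on an aromatic carbon gives a 1.1-fold higher number from compound 3 to compound 4 (0.03 log units; within the scatter), and this step agrees with the one seen on the other core: the same change on two cores in this assay, a 1.1-fold higher number (0.04 log units; within the scatter) from compound 2 to compound 1 and a 1.1-fold higher number (0.03 log units; within the scatter) from compound 3 to compound 4, 1.0-fold (0.01 log units) apart, within the scatter of two such steps

Across the two cores shown, the exchange of these two halogens therefore leaves the number unchanged within the scatter, and the core of compound 3 gives no reading different from that of the core of compound 2. This does not show that the change has a real effect that carries over, since two steps within the scatter offer no measurable effect to transfer, and two cores give no basis for a rule covering other cores in the series.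

All four compounds shown carry either chloro or bromo at this place, so it remains open how a markedly different group there, such as a nitrile, an amine or a carboxylic acid, would read in this assay. The methyl group is also the same throughout, which leaves open what a longer chain or a hydrogen in its place would do, and whether any such change would carry from one core to the other.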